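The source may hold more compounds than are shown below. What is called first, only, known or untested is meant among the compounds shown, and "the series" means these compounds.

Measured so far in a functional assay on RPMI-8226 cells (Homo sapiens) for inhibition, read by sulforhodamine B assay, with a stated time of 48 h; on this read-out higher numbers stand for weaker inhibition of growth and lower numbers for stronger inhibition of growth:

compound 1, `N#C/C(=C\c1c(-c2ccccc2)[nH]c2ccccc12)C(=O)c1ccccc1`, giving 2400 nM
compound 2, `O=C(/C(=C\c1c(-c2ccccc2)[nH]c2ccccc12)S(=O)(=O)c1ccccc1)c1ccccc1`, giving 7600 nM
compound 3, `COc1ccc(-c2[nH]c3ccc(OC)cc3c2/C=C(\C#N)S(=O)(=O)c2ccccc2)cc1`, giving 1300 nM

Compound 2 stands at the highest number of the three, which on this read-out means the weakest inhibition of growth. Its nearest neighbour is compound 1, whose number is lower by a margin beyond the usual scatter, and compound 3 lies further still, also beyond the scatter.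

Compound 4, `CC(=O)/C(=C\c1c(-c2ccccc2)[nH]c2ccccc12)S(=O)(=O)c1ccccc1`, has not yet been measured in this assay. It differs from compound 2 in a single place: methyl in place of phenyl on a carbonyl carbon. Cut one bond further out, the same change reads benzoyl to acetyl. Going by the values given here, none of the measured pairs differs in this way, so there is no measured step to lean on; the differences among compounds 1, 2 and 3 lie elsewhere in the molecule.

With nothing pointing in either direction, the expected step of a 1.3-fold lower number from compound 2 to compound 4 (0.10 log units; within the scatter) is small, most likely not beyond the scatter, with a wide range on both sides. Compound 4 is therefore estimated at about 6000 nM, expected to fall between 2000 nM and 20000 nM.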

Compound 4, concentration for 50% growth inhibition: 2200 nM
Estimate against measurement, compound 4: 2.7-fold (0.44 log units) above; measured number inside the range.
By their numbers in this assay, from the lowest: compounds 3, 4 and 1 (each within the scatter of the next); then compound 2.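

In this assay, going by these compounds alone, this is the first measured change at the carbonyl carbon, and it gives a 3.5-fold lower number from compound 2 to compound 4 (0.54 log units; beyond the scatter), a step beyond the scatter. What this group is therefore matters to growth inhibition, and here the swap of phenyl for methyl, which reads benzoyl to acetyl one bond further out, goes with stronger inhibition, so in this pair the aromatic ring on the carbonyl carbon is not required for activity. Nothing measured alongside these compounds says why the number moves, so the step stands as an observation from one pair only.

From the compounds shown here alone, with only phenyl and methyl compared on this carbonyl carbon, it remains open how a longer chain such as ethyl or propyl, or an amine in the same place, would behave, and so whether the numbers follow any trend across such groups. It is also open whether benzoyl to acetyl would give a similar step on the core of compound 1, since that compound has no acetyl partner among those shown.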